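A few compounds are considered here, and "the series" means these few. Any claim that something is new, unique, unknown or untested is made for them only; others in the source may bear on it.

Compounds measured in an assay for inhibition of squalene synthase (Rattus norvegicus), using microsomes; on this read-out higher numbers stand for weaker inhibition and lower numbers for stronger inhibition:

Compound 1 `CCC(=O)Nc1ccc(OCC(O)CNC(C)C)c(Cc2ccccc2)c1` gives 900 nM.
Compound 2 `CC(C)NCC(O)COc1ccccc1Cc1ccccc1` gives 8800 nM.
Compound 3 `C=CCc1cc(C(=O)CCC)ccc1OCC(O)CNC(C)C` gives 4.5 nM.

Compound 1 stands second highest of the three numbers in this assay, nearest to compound 2 and furthest from compound 3. Compound 4 `CCC(=O)Nc1ccc(OCCCNC(C)C)c(Cc2ccccc2)c1` differs from compound 1 by hydrogen in place of hydroxy on a saturated chain carbon bound to two saturated chain carbons. Among the compounds with values here, the only measured step, a 9.8-fold higher number from compound 1 to compound 2 (0.99 log units; beyond the scatter), concerns the propanoylamino group on the aromatic ring and not the chain, so no measured step bears directly on the hydroxy. Compound 3 keeps the hydroxy and still differs at two other places, so its value gives no guide either. Within the data shown here, with no comparable step in hand, compound 4 is expected to lie close to compound 1, with a wide range; the step of a 2.0-fold higher number from compound 1 to compound 4 (0.30 log units; within the scatter) is the estimate, and compound 4 is expected to give 1800 nM (from 500 nM to 7000 nM).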

Compound 4, half-maximal inhibitory concentration: 0.6 nM
Compound 4: middle estimate off by 3000-fold (3.48 log units), on the high side, and the stated range ends above it.
By their numbers in this assay, from the lowest: compound 4; then compound 3; then compound 1; then compound 2.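

In this assay, putting hydrogen in place of hydroxy on this saturated chain carbon bound to two saturated chain carbons gives a 1500-fold lower number from compound 1 to compound 4 (3.18 log units; beyond the scatter) and a large change. The earlier compounds shown here left this position untested, and the step shows that the read-out is highly sensitive to this one change on the core of compound 1. No available evidence accounts for the step.

As far as these compounds go, it remains open whether the same change would act alike on the core of compound 3. Also open, from the compounds shown here alone, is how a methoxy or fluorine on this carbon, or a longer chain, would compare with compound 4.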